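Series notes: ethoxycarbonyl to tert-butoxycarbonyl

The source may report more compounds than this note shows. Statements on the series, on what has been measured and on what is new or still open speak of the compounds shown alone.

compound 1 `CCCCC(=O)N1CCC(N2CCN(C(=O)c3c(NC(=O)NCC)sc4ccccc34)CC2)CC1` - "not determined" (no result reported)
compound 2 `CCNC(=O)Nc1sc2ccccc2c1C(=O)N1CCN(C2CCN(C(=O)CC(C)C)CC2)CC1` - "not determined" (no result reported)
compound 3 `CCNC(=O)Nc1sc2ccccc2c1C(=O)N1CCN(C2CCN(C(=O)OCC)CC2)CC1` - 228 nM

For the measured compounds named here, in a functional assay on HepG2 cells (Homo sapiens) for inhibition, read by scintillation counting, with a stated time of 2 h (on this read-out lower numbers stand for stronger inhibition and higher numbers for weaker inhibition), compound 3 gives 228 nM, and this is the only number available so far. Compound 1 and compound 2 returned no result, so compound 3 cannot yet be ranked against anything, and no pair of measured compounds offers a step to reason from.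

The next compound to be tested is compound 4 `CCNC(=O)Nc1sc2ccccc2c1C(=O)N1CCN(C2CCN(C(=O)OC(C)(C)C)CC2)CC1`. It carries tert-butyl in place of ethyl on an oxygen next to a carbonyl group. Everything else is shared with compound 3.

Going by the values given here, with no measured precedent, any expectation for this assay is weakly founded and rests only on compound 3 at 228 nM and this one change. A modest move towards stronger inhibition is expected, though a result within the usual scatter would be no surprise. The estimated change is a 1.8-fold lower number from compound 3 to compound 4 (0.24 log units; within the scatter). Compound 4 is expected at about 130 nM, with an estimated range of 35 nM to 500 nM.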

Compound 4, half-maximal inhibitory concentration: 79 nM
Compound 4: middle estimate off by 1.6-fold (0.22 log units), on the high side; measured number inside the range.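

In this assay, for the compounds shown here, tert-butyl in place of ethyl on an oxygen next to a carbonyl group gives a 2.9-fold lower number from compound 3 to compound 4 (0.46 log units; beyond the scatter), the first readable step. This position is therefore sensitive to the group on that oxygen, and the change from ethoxycarbonyl to tert-butoxycarbonyl goes with stronger inhibition rather than a loss of it. No measured evidence bears on why the number moves.

A single step between two compounds cannot show whether the gain depends on the branching of tert-butyl or simply follows the larger carbon count, so a longer chain or a cyclohexyl group on the same oxygen remains an open comparison. Also open, as far as these compounds go, is whether the oxygen itself matters, as an amine nitrogen in its place would test, and compound 1 and compound 2 give no number to bear on this.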